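Swapping a chlorophenoxypropyl ether for a methoxyphenyl carbamate

The source may report more compounds than this note shows. Statements on the series, on what has been measured and on what is new or still open speak of the compounds shown alone.

Three compounds sharing one core were tested in a functional assay on PANC-1 cells (Homo sapiens) for inhibition, read by MTT assay, with a stated time of 24 h, tested at 10 uM; a lower number here means less inhibition, a higher number more inhibition at the concentration tested (going by the name of the read-out). Compound 1 `COc1ccc(NC(=O)Oc2cc(=O)n(CCCO)c3c2CC(CC=C(C)C)C(C)(C)C3)cc1` gives 3.7% in this assay. Compound 2 `CC(C)=CCC/C(C)=C/CC1Cc2c(OCCCNC(=O)c3ccco3)cc(=O)n(CCCO)c2CC1(C)C` gives 69.5% in this assay. Compound 3 `CC(C)=CCC/C(C)=C/CC1Cc2c(OCCCOc3ccc(Cl)cc3)cc(=O)n(CCCO)c2CC1(C)C` gives 25.2% in this assay, which places it second of the three numbers: below compound 2 and above compound 1, both gaps beyond the scatter.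

The only measured step among these compounds, a number 44.3 percentage points lower from compound 2 to compound 3 (beyond the scatter), exchanged the group on the propyl chain and was large. The step now followed leads to compound 4 `COc1ccc(NC(=O)Oc2cc(=O)n(CCCO)c3c2CC(C/C=C(\C)CCC=C(C)C)C(C)(C)C3)cc1`, where ((4-methoxyphenyl)carbamoyl in place of 3-(4-chlorophenoxy)propyl on an oxygen on an aromatic ring). Compound 3 and compound 4 share the long side chain on the core, so the structural change is confined to the group hanging from the oxygen on the aromatic ring.

Within the data shown here, no measured step carries exactly this change, but compound 1 carries the same ((4-methoxyphenyl)carbamoyl)oxy group on the core and gives only 3.7% in this assay. On that basis compound 4 is expected to sit low, a step of a number 17.2 percentage points lower from compound 3 to compound 4 (beyond the scatter) downward. The estimate for compound 4 in this assay is 8%, within a range from 0% to 25%.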

Compound 4, a percentage reported as inhibition, at one concentration (the size of the read-out at that concentration, not a potency): 64.1%
The estimate for compound 4 lay 56.1 percentage points below the measured number; the whole stated range lies below it.
By their numbers in this assay, from the lowest: compound 1; then compound 3; then compounds 4 and 2 (each within the scatter of the next).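

At this oxygen on an aromatic ring, the (4-methoxyphenyl)carbamoyl group can give a high number: in this assay, the number with it is far higher than with 3-(4-chlorophenoxy)propyl on the shared core (a number 38.9 percentage points higher from compound 3 to compound 4 (beyond the scatter)). The low number of compound 1 therefore does not follow from this group alone, since the same group gives a very different result once 3-methylbut-2-en-1-yl replaces hydrogen on a saturated chain carbon bound to a double-bonded chain carbon (a number 60.4 percentage points higher from compound 1 to compound 4 (beyond the scatter)). The group also cannot be told apart from 3-(((furan-2-yl)carbonyl)amino)propyl at this oxygen (a number 5.4 percentage points lower from compound 2 to compound 4 (within the scatter)), so two quite different groups give similar numbers here, while 3-(4-chlorophenoxy)propyl stands apart from both.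

No measurement at hand explains any of these differences. Also open, going by these compounds, is how a (4-chlorophenyl)carbamoyl group, or a carbamoyl group with a methyl on its nitrogen, would read at this oxygen on the same core, and whether these numbers, each taken at one concentration, would hold at other concentrations.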